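The source may hold more compounds than are shown below. What is called first, only, known or untested is meant among the compounds shown, and "the series" means these compounds.

Compound 1 `Cc1ccc(/C=C2\SC(=O)N(CCNC(=O)Nc3c(C)n(C)n(-c4ccccc4)c3=O)C2=O)cc1` and compound 2 `COc1ccc(/C=C2\SC(=O)N(CCNC(=O)Nc3c(C)n(C)n(-c4ccccc4)c3=O)C2=O)cc1` share one core, and compound 3 `Cc1ccc(/C=C2\SC(=O)N(CC(=O)Nc3c(C)n(C)n(-c4ccccc4)c3=O)C2=O)cc1` and compound 4 `COc1ccc(/C=C2\SC(=O)N(CC(=O)Nc3c(C)n(C)n(-c4ccccc4)c3=O)C2=O)cc1` share another; the difference between the two cores is not broken down here. In a toxicity assay on WI-38 cells (Homo sapiens) for inhibition, read by MTT assay, with a stated time of 48 h (a higher number here means a weaker inhibitor, a lower number a stronger inhibitor), compound 1 gives 48100 nM, compound 2 gives 34500 nM, and compound 3 gives 83700 nM. The change methoxy in place of methyl on an aromatic carbon made the step of a 1.4-fold lower number from compound 1 to compound 2 (0.14 log units; within the scatter). Compound 4 carries the same change, (methoxy in place of methyl on an aromatic carbon), on the core of compound 3; its place is the same, so it is the same change. The step from compound 3 to compound 4 is expected to be a 1.4-fold lower number from compound 3 to compound 4 (0.14 log units; within the scatter), resting on the step of a 1.4-fold lower number from compound 1 to compound 2 (0.14 log units; within the scatter). Compound 4 is therefore estimated at 60000 nM in this assay, most likely between 30000 nM and 120000 nM.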

Compound 4, half-maximal inhibitory concentration: 52900 nM
Compound 4: the middle estimate sits 1.1-fold (0.05 log units) above what was measured; the measured number falls inside the stated range.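

In this assay, replacing 4-methylphenyl with 4-methoxyphenyl gives a 1.6-fold lower number from compound 3 to compound 4 (0.20 log units; within the scatter), and this step agrees with the earlier one on the other core: the same change on two cores in this assay, a 1.4-fold lower number (0.14 log units; within the scatter) from compound 1 to compound 2 and a 1.6-fold lower number (0.20 log units; within the scatter) from compound 3 to compound 4, 1.1-fold (0.05 log units) apart, within the scatter of two such steps. In these two pairs, then, the change carried over from one core to the other at much the same size. This does not show that the change has a real effect, as each step lies within the scatter, and two pairs are too few to predict the result on other cores.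

The compounds shown leave open what a chlorine atom, a hydroxyl or an amine would do in the same place. They also leave open whether the agreement would hold with a longer chain in the core.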